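The source may report more compounds than this note shows. Statements on the series, on what has been measured and on what is new or still open speak of the compounds shown alone.

In a functional assay on HT-29 cells (Homo sapiens) for antiproliferative activity (a lower number here means a stronger inhibitor, a higher number a weaker inhibitor), compound 1 `COc1ccc(S(=O)(=O)N2CCc3cccc(Nc4ccc(O)cc4)c32)cc1` gives 511 nM and compound 2 `COc1ccc(Nc2cccc3c2N(S(=O)(=O)c2ccc(OC)cc2)CC3)cc1` gives 803 nM. For the measured compounds named here, the two values lie within the scatter of each other, so compound 2 stands level with the only other compound measured on this shared core. Compound 3 `COc1ccc(S(=O)(=O)N2CCc3cccc(Nc4ccc(Cl)cc4)c32)cc1` keeps that core and carries chloro in place of methoxy on an aromatic carbon, para to a large group: chloro in place of methoxy on an aromatic carbon. Going by the values given here, only one measured step bears on this group, methyl in place of hydrogen on an oxygen on an aromatic ring, and it is small: a 1.6-fold higher number from compound 1 to compound 2 (0.20 log units; within the scatter). Among the compounds with values here, no chloro compound has been measured, so the direction rests on little. The expected change is therefore no larger than the scatter, namely a 1.5-fold lower number from compound 2 to compound 3 (0.16 log units; within the scatter). For compound 3 the estimated value is 550 nM, with an expected range of 180 nM to 1700 nM.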

Compound 3, half-maximal inhibitory concentration: 658 nM
Beside the measured number, compound 3's estimate is 1.2-fold (0.08 log units) below it; low and high end bracket the measured number.
By their numbers in this assay, from the lowest: compounds 1, 3 and 2 (each within the scatter of the next).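

In this assay chloro in place of methoxy gives a 1.2-fold lower number from compound 2 to compound 3 (0.09 log units; within the scatter) and chloro in place of hydroxy gives a 1.3-fold higher number from compound 1 to compound 3 (0.11 log units; within the scatter) on the same aromatic carbon, para to a large group. The earlier pair had only oxygen-linked groups at this position, and the result now shows that a chloro group, with no oxygen, also leaves the number within the scatter of both, so hydroxy, methoxy and chloro stand level here. Nothing available accounts for this level reading.

From the compounds shown here alone, whether an amine, a carboxylic acid or a longer chain on this aromatic carbon would move the number beyond the scatter remains open. Also open, going by these compounds, is whether this level reading would hold for other changes to the shared core.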